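Swapping chloro for methyl on the pyrazole of compound 1

The source may report more compounds than this note shows. Statements on the series, on what has been measured and on what is new or still open speak of the compounds shown alone.

Two glucagon receptor antagonists have been measured so far. Compound 1 `CCCC(Oc1ccc(-n2cc(Cl)cn2)cc1)c1ccc(C(=O)NCCC(=O)O)cc1` gives 6500 nM in a functional assay on cells for antagonist activity at Glucagon receptor (Homo sapiens), read by cAMP accumulation, in the presence of a further agent that is not named here (a lower number here means a stronger inhibitor, a higher number a weaker inhibitor), the lowest of the two numbers. Compound 2 `O=C(O)CCNC(=O)c1ccc(C(Oc2ccc(-n3cc(C(F)(F)F)cn3)cc2)C2CC2)cc1` gives 15000 nM in this assay, a gap beyond the usual scatter. Compound 3 `CCCC(Oc1ccc(-n2cc(C)cn2)cc1)c1ccc(C(=O)NCCC(=O)O)cc1` has not been measured; it differs from compound 1 by methyl in place of chloro on an aromatic carbon. Among the compounds with values here, with no pair of measured compounds showing the same change, the step is expected to be small, likely within the scatter or slightly weakening: a 1.4-fold higher number from compound 1 to compound 3 (0.14 log units; within the scatter). Compound 3 is therefore estimated at 9000 nM, with a range from 4000 nM to 20000 nM.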

Compound 3, antagonist equilibrium constant: 11000 nM
Compound 3: the middle estimate sits 1.2-fold (0.09 log units) below what was measured, and the stated range covers the measured number.
By their numbers in this assay, from the lowest: compounds 1, 3 and 2 (each within the scatter of the next, the first and the last beyond it).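

At this position, on an aromatic carbon of the five-membered aromatic ring with 2 nitrogen, methyl in place of chloro gives a 1.7-fold higher number from compound 1 to compound 3 (0.23 log units; within the scatter) in this assay. This first single-place comparison therefore does not separate 4-chloro-1H-pyrazol-1-yl from 4-methyl-1H-pyrazol-1-yl. No measurement available here offers an explanation for this result. Going by these compounds, whether a nitrile, an amine or a methoxy group at this position would separate from chloro and methyl remains open. Compound 2 differs from compound 1 in more than one place, so its trifluoromethyl cannot be read on its own.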